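Swapping an aryl amide for a hydroxyacetamide

A few compounds are considered here, and "the series" means these few. Any claim that something is new, unique, unknown or untested is made for them only; others in the source may bear on it.

Of the compounds shown here, two built on one shared core have been tested in an assay on cells for inhibition of Amine oxidase [flavin-containing] B (Homo sapiens), read by fluorescence and Amplex Red, with stated times of 30 min and 15 min; a higher number here means a weaker inhibitor, a lower number a stronger inhibitor. Compound 1 `C#CCNC1CCc2c(OCCc3cc(NC(=O)C(C)(C)C)ccc3F)cccc21` gives only a limit of the assay, > 20000 nM. Compound 2 `C#CCNC1CCc2c(OCCc3cc(NC(=O)c4cccc(F)c4)ccc3Cl)cccc21` likewise gives only a limit in this assay, > 20000 nM. Compound 2 thus stands at the limit of > 20000 nM in this assay, at which 2 of the 2 values shown sit, and a limit allows no ranking against anything else. Compound 3 `C#CCNC1CCc2c(OCCc3cc(NC(=O)CO)ccc3Cl)cccc21` has not yet been measured. It differs from compound 2 in one place: hydroxymethyl in place of 3-fluorophenyl on a carbonyl carbon. With no measured step between compounds and both known values sitting at the limit, nothing shown points in a direction; the step is expected to be none beyond the scatter, a step that the limit leaves unreadable from compound 2 to compound 3. Compound 3 is expected to give about 40000 nM in this assay, within 10000 nM to 200000 nM, and most probably again as a limit rather than a number.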

Compound 3, half-maximal inhibitory concentration: 270 nM
Beside the measured number, compound 3's estimate is 150-fold (2.17 log units) above it; measured number outside the range, below it.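

Until now the shared core had given only limits, so nothing showed that these compounds could give a readable number in this assay at all. Changing only the group on the carbonyl carbon gives an at least 74-fold lower number from compound 2 to compound 3 (1.86 log units; beyond the scatter), which makes this position one that can decide between a readable number and none. Compound 3 is the only one of the three with a number, and the true size of the step stays unknown, as the other two compounds rest at one shared limit: the limit of > 20000 nM in this assay, at which 2 of the 3 values shown sit.

As far as these compounds go, whether the change works through the hydroxyl group or through the loss of the 3-fluorophenyl ring stays open. A plain methyl, a methoxymethyl or an aminomethyl on the same carbonyl carbon would tell these two readings apart, and a longer chain ending in a hydroxyl would show how much room there is for change at this position.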